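Furan for thiophene at the limit of a cell assay

The source may hold more compounds than are shown below. What is called first, only, known or untested is meant among the compounds shown, and "the series" means these compounds.

Measured so far in a functional assay on A549 cells (Homo sapiens), read by MTT assay, with a stated time of 72 h; a higher number here means a weaker inhibitor, a lower number a stronger inhibitor:
Compound 1 `COc1ncnc2c1c(-c1cccs1)cn2[C@@H]1O[C@H](CO)[C@@H](O)[C@H]1O` gives 4850 nM in this assay.
Compound 2 `Cc1ncnc2c1c(-c1cccs1)cn2[C@@H]1O[C@H](CO)[C@@H](O)[C@H]1O` gives > 20000 nM in this assay, which is a limit of the assay.
Compound 3 `CNc1ncnc2c1c(-c1cccs1)cn2[C@@H]1O[C@H](CO)[C@@H](O)[C@H]1O` gives > 20000 nM in this assay, again a limit of the assay.

Compound 3 stands at the top of the numbers shown, with only a limit and no figure of its own. The steps that are readable both start from compound 1: an at least 4.1-fold higher number from compound 1 to compound 2 (0.61 log units; beyond the scatter) and an at least 4.1-fold higher number from compound 1 to compound 3 (0.61 log units; beyond the scatter), both reaching (the limit of > 20000 nM in this assay, at which 2 of the 3 values shown sit). The step between compound 2 and compound 3, a step that the two limits leave unreadable from compound 2 to compound 3, gives no size.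

Compound 4 `CNc1ncnc2c1c(-c1ccco1)cn2[C@@H]1O[C@H](CO)[C@@H](O)[C@H]1O` differs from compound 3 in one place: furan-2-yl in place of thiophen-2-yl on an aromatic carbon. For the measured compounds named here, none of the measured steps touches this part of the core; they all concern the group on the six-membered ring. Going by the values given here, the change from compound 3 to compound 4 therefore has no measured precedent here, and the only anchor is that compound 3 already sits at the limit. In this assay compound 4 is expected to give 25000 nM, with a range from 8000 nM to 60000 nM. This estimate corresponds to an expected step that the limit leaves unreadable from compound 3 to compound 4, most likely again reported only as a limit.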

Compound 4, half-maximal inhibitory concentration: 2570 nM
Estimate against measurement, compound 4: 9.7-fold (0.99 log units) above; measured number outside the range, below it.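

The group at this position of the shared core, on an aromatic carbon of the five-membered ring two ring bonds from the ring nitrogen, has a clear effect in this assay: furan-2-yl in place of thiophen-2-yl gives an at least 7.7-fold lower number from compound 3 to compound 4 (0.89 log units; beyond the scatter). For the compounds shown here, all the earlier steps concerned the group on the six-membered ring, so this is the first readable evidence on this position, and it shows that methylamino on the six-membered ring does not hold a compound at the limit when furan-2-yl replaces thiophen-2-yl, a change in which sulfur leaves and oxygen enters the ring. The step can be stated only as a minimum, because compound 3 has a limit and no figure of its own: the limit of > 20000 nM in this assay, at which 2 of the 4 values shown sit.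

The compounds shown leave open whether furan-2-yl would bring a comparable change alongside methoxy or methyl on the six-membered ring, since this step rests on the methylamino pair alone. As far as these compounds go, how a phenyl ring or a pyrrole ring at the same place would read in this assay also remains open.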